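Two Methylphenyl Esters of One Shared Core

The source may report more compounds than this note shows. Statements on the series, on what has been measured and on what is new or still open speak of the compounds shown alone.

Compound 1 `CC(=O)Oc1ccccc1C(=O)O[C@H]1CO[C@H]2[C@@H]1OC[C@H]2OC(C)=O`: 0.0095 h
Compound 2 `CC(=O)Oc1ccccc1C(=O)O[C@H]1CO[C@H]2[C@@H]1OC[C@H]2OC(=O)c1ccccc1C`: 0.0138 h

In an ADME assay on a cell-free system (plasma, Homo sapiens) for metabolic stability, with Plasma (Rattus norvegicus) as the target, read by HPLC, at pH 7.4 (a lower number here means that the compound disappears faster, a higher number that the compound lasts longer), compound 1 gives 0.0095 h and compound 2 gives 0.0138 h. For the measured compounds named here, the only measured step, a 1.5-fold higher number from compound 1 to compound 2 (0.16 log units; within the scatter), leaves the two values within the scatter of one another, so compound 2 does not stand apart from compound 1 on the numbers at hand. Compound 3 `CC(=O)Oc1ccccc1C(=O)O[C@H]1CO[C@H]2[C@@H]1OC[C@H]2OC(=O)c1ccc(C)cc1` is the next member; relative to compound 2 it carries 4-methylphenyl in place of 2-methylphenyl on a carbonyl carbon. Going by the values given here, no measured step exchanges one methylphenyl for another, so the single step on record, a 1.5-fold higher number from compound 1 to compound 2 (0.16 log units; within the scatter), which replaced a methyl with a 2-methylphenyl on the same carbonyl carbon and stayed within the scatter, is the only guide, and it bears on the present change only loosely. Among the compounds with values here, the group on the carbonyl carbon keeps the same count of atoms and the same ring, and the one measured change to this part of the molecule produced nothing beyond the scatter. For compound 3 the expected step is therefore none beyond the scatter, a 1.0-fold higher number from compound 2 to compound 3 (0.01 log units; within the scatter). Compound 3 is estimated at 0.014 h in this assay, with a range from 0.006 h to 0.035 h.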

Compound 3, half-life: 0.0362 h
Beside the measured number, compound 3's estimate is 2.6-fold (0.41 log units) below it; the measured number lies above the stated range.
By their numbers in this assay, from the lowest: compounds 1 and 2 (each within the scatter of the next); then compound 3.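

In this assay, exchanging 2-methylphenyl for 4-methylphenyl on a carbonyl carbon whose other neighbour is oxygen next to a carbonyl group gives a 2.6-fold higher number from compound 2 to compound 3 (0.42 log units; beyond the scatter), a modest change. Compounds 1 and 2 could not show this: two groups with the same atoms, joined differently, are not interchangeable at this position. Measured against the methyl group, 4-methylphenyl gives a 3.8-fold higher number from compound 1 to compound 3 (0.58 log units; beyond the scatter), whereas 2-methylphenyl gives only a 1.5-fold higher number from compound 1 to compound 2 (0.16 log units; within the scatter), so among these three compounds, carrying an aromatic ring on this carbonyl carbon does not by itself set the number apart, and no measurement at hand accounts for the difference between the two methylphenyl groups.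

The compounds shown leave open how an unsubstituted phenyl group, a butyl chain or a pyridine ring on this carbonyl carbon would compare with 4-methylphenyl. They also leave open whether an amide in place of this ester linkage would give a higher number than any of the three esters here.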